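The source may report more compounds than this note shows. Statements on the series, on what has been measured and on what is new or still open speak of the compounds shown alone.

Measured so far in a functional assay on B16-F10 cells (Mus musculus) for inhibition, read by MTT assay, with a stated time of 72 h; a higher number here means a weaker inhibitor, a lower number a stronger inhibitor: compound 1 `N#Cc1c(Nc2ccc(F)cc2)nc(SCc2cn(Cc3ccccc3Cl)nn2)nc1-c1ccccc1` gives 5340 nM; compound 2 `Cc1ccccc1Nc1nc(SCc2cn(Cc3ccccc3Cl)nn2)nc(-c2ccccc2)c1C#N` gives 2760 nM. Compound 3 `Cc1ccccc1Nc1nc(SCc2cn(Cc3ccc(Cl)cc3)nn2)nc(-c2ccccc2)c1C#N` gives > 64000 nM, which is a limit of the assay and not a number.

Compound 3 thus stands at the limit (the limit of > 64000 nM in this assay, at which 1 of the 3 values shown sits), where the other two compounds give numbers. Compound 4 `Cc1ccc(Cn2cc(CSc3nc(Nc4ccccc4C)c(C#N)c(-c4ccccc4)n3)nn2)cc1` differs from compound 3 by methyl in place of chloro on an aromatic carbon. The step that bears on it is an at least 23-fold higher number from compound 2 to compound 3 (1.36 log units; beyond the scatter), where replacing 2-chlorophenyl with 4-chlorophenyl on the benzyl group cost heavily; compound 4 keeps the 4-substituted benzyl and only exchanges chloro for methyl. The step of a 1.9-fold lower number from compound 1 to compound 2 (0.29 log units; within the scatter) touched another part and stayed within the scatter. Going by the values given here, no measured step compares chloro with methyl. Compound 4 is therefore expected to remain near the limit, with an expected step that the limit leaves unreadable from compound 3 to compound 4 of no clear size. The estimate for compound 4 is 80000 nM, within 20000 nM to 300000 nM.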

Compound 4, half-maximal inhibitory concentration: > 64000 nM
Compound 4: no number, only a limit; the forecaster's own chance of this, stated with the estimate: 70%; the middle value is on the limit's open side.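

Compound 4 gives > 64000 nM in this assay, which is a limit of the assay and not a number. So a second group, 4-methylbenzyl, also ends at this limit, with an at least 23-fold higher number from compound 2 to compound 4 (1.36 log units; beyond the scatter) against the 2-chlorophenyl group of compound 2, and chloro is not needed on that carbon for this result. The step from 4-chlorobenzyl to 4-methylbenzyl cannot be read, because both compounds rest on the same limit: the limit of > 64000 nM in this assay, at which 2 of the 4 values shown sit.

Going by these compounds, whether either group is the weaker stays open. So does whether an unsubstituted benzyl group, or an amine or a methoxy group in place of the chloro on that aromatic carbon, would give a number.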